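The source may report more compounds than this note shows. Statements on the series, on what has been measured and on what is new or still open speak of the compounds shown alone.

Among the compounds with values here, in a functional assay on HEK293 cells for agonist activity at D(4) dopamine receptor (Homo sapiens), read by FLIPR (a lower number here means that less compound is needed, a higher number that more compound is needed for the effect), the compounds measured so far are: compound 1, `C=Cc1cccc(C(=O)NCN2CCC(c3cccc[n+]3[O-])CC2)c1`, 68 nM; compound 2, `Cc1cc(F)ccc1NC(=O)CN1CCC(c2cccc[n+]2[O-])CC1`, 60 nM; compound 3, `COc1ccccc1C1CCN(CC(=O)Nc2cccc(C)c2)CC1`, 420 nM.

Compound 1 holds the second highest of these three numbers. Compound 2 lies within the usual scatter of compound 1, so the two cannot be told apart. Compound 3 gives the higher number, and that gap stands beyond the scatter. Compound 4, `O=C(NCN1CCC(c2cccc[n+]2[O-])CC1)c1ccc(F)c(Cl)c1`, is not yet measured; it differs from compound 1 by 3-chloro-4-fluorophenyl in place of 3-vinylphenyl on a carbonyl carbon. Within the data shown here, no step of this kind has been measured yet. The group that leaves and the group that enters are counted alike in heavy atoms, and neither carries donors or acceptors, so in this assay only a small step is expected, a 1.4-fold lower number from compound 1 to compound 4 (0.13 log units; within the scatter), not clearly beyond the scatter. Compound 4 is accordingly estimated at 50 nM, with a range from 20 nM to 150 nM.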

Compound 4, half-maximal effective concentration: 63 nM
Estimate against measurement, compound 4: 1.3-fold (0.10 log units) below; low and high end bracket the measured number.
By their numbers in this assay, from the lowest: compounds 2, 4 and 1 (each within the scatter of the next); then compound 3.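

In this assay the exchange of 3-vinylphenyl for 3-chloro-4-fluorophenyl on a carbonyl carbon gives a 1.1-fold lower number from compound 1 to compound 4 (0.03 log units; within the scatter) and so shows that this position takes either aromatic group without a change that can be told from the scatter. Within the data shown here, it is the first step read at this place, which the earlier compounds could not offer. No measurement at hand gives a reason for this outcome. The compounds shown leave open whether a cyclohexyl group or a short alkyl chain in place of the aromatic ring would hold the number, and how an amine or a carboxylic acid on that ring would fare.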